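The compounds below may be only part of what the source reports. "The series", "measured", "known", "first", "only" and "open" are said of these compounds alone.

Three compounds that share one core and differ only in the group on an oxygen on an aromatic ring have been tested in a functional assay on HCT-116 cells (Homo sapiens) for antiproliferative activity, read by MTT assay, with a stated time of 48 h; on this read-out lower numbers stand for stronger inhibition and higher numbers for weaker inhibition. Compound 1 `CCOc1cc(-c2ccc3c(ccn3C)c2)cn2c(-c3cc(OC)c(OC)c(OC)c3)nnc12`, carrying ethyl, gives 228 nM. Compound 2 `COc1cc(-c2nnc3c(OC(C)C)cc(-c4ccc5c(ccn5C)c4)cn23)cc(OC)c1OC`, carrying isopropyl, gives 402 nM. Compound 3 `COc1cc(-c2nnc3c(OC4COC4)cc(-c4ccc5c(ccn5C)c4)cn23)cc(OC)c1OC`, carrying oxetan-3-yl, gives 1290 nM, the highest number of the three and so the weakest inhibitor in this small set.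

Compound 4 `COc1cc(-c2nnc3c(OCC(F)(F)F)cc(-c4ccc5c(ccn5C)c4)cn23)cc(OC)c1OC` differs from compound 3 by a single swap: 2,2,2-trifluoroethyl in place of oxetan-3-yl on an oxygen on an aromatic ring. In words, this puts 2,2,2-trifluoroethyl in place of oxetan-3-yl on an oxygen on an aromatic ring.

Going by the values given here, three measured steps bear on this swap. Among the open chains there is a 1.8-fold higher number from compound 1 to compound 2 (0.25 log units; within the scatter). Moving to the ring gives a 5.7-fold higher number from compound 1 to compound 3 (0.75 log units; beyond the scatter), and also a 3.2-fold higher number from compound 2 to compound 3 (0.51 log units; beyond the scatter). The two compounds without a ring therefore sit together, and compound 3 stands apart from them. Among the compounds with values here, the incoming group also has no ring and is built on an ethyl chain, but no fluorine-bearing compound has been measured, so the comparison is uncertain. The expected change is a modest drop, estimated as a 2.9-fold lower number from compound 3 to compound 4 (0.46 log units; beyond the scatter). For compound 4 the estimated value is 450 nM, with an expected range from 170 nM to 1200 nM.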

Compound 4, half-maximal inhibitory concentration: 483 nM
Estimate against measurement, compound 4: 1.1-fold (0.03 log units) below; low and high end bracket the measured number.
By their numbers in this assay, from the lowest: compounds 1, 2 and 4 (each within the scatter of the next, the first and the last beyond it); then compound 3.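

In this assay, 2,2,2-trifluoroethyl in place of oxetan-3-yl gives a 2.7-fold lower number from compound 3 to compound 4 (0.43 log units; beyond the scatter), so a third open chain, this one carrying fluorine, also lies clear of the ring-bearing compound 3. Fluorine on the chain does leave a small mark in one comparison: trifluoromethyl in place of methyl gives a 2.1-fold higher number from compound 1 to compound 4 (0.33 log units; beyond the scatter), a modest step beyond the scatter, whereas 2,2,2-trifluoroethyl in place of isopropyl gives a 1.2-fold higher number from compound 2 to compound 4 (0.08 log units; within the scatter), so those two compounds cannot be put in order. No accompanying measurement accounts for any of these differences, so the numbers describe what happens at this position without saying how it comes about.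

The oxetan-3-yl group differs from the open chains both in having a ring and in having an oxygen atom within the group, and the compounds shown cannot separate those two features. A cyclobutyl group, with a ring and no such oxygen, and a 2-methoxyethyl group, with that oxygen and no ring, would pull them apart, while a chain ending in an amine would test a different kind of group at this position.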